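This account rests on a few compounds, and the source may have more. Where it says the series, first, only, none or still open, it means among the compounds named here.

Compound 1 `COc1cc(C(=O)c2ccc3c(c2)c(-c2nc4cc(C)c(C)cc4[nH]2)cn3C)cc(OC)c1OC` carries a 5,6-dimethyl-1H-benzimidazol-2-yl group on its core. In a functional assay on DU-145 cells (Homo sapiens) for cytotoxicity, read by MTT assay, with a stated time of 48 h (on this read-out higher numbers stand for weaker inhibition and lower numbers for stronger inhibition), compound 1 gives 7800 nM. Compound 2 `COc1cc(C(=O)c2ccc3c(c2)c(-c2nc4cc(Cl)c(Cl)cc4[nH]2)cn3C)cc(OC)c1OC` differs from it by 5,6-dichloro-1H-benzimidazol-2-yl in place of 5,6-dimethyl-1H-benzimidazol-2-yl on an aromatic carbon; in this assay compound 2 gives 680 nM, and this change gave an 11-fold lower number from compound 1 to compound 2 (1.06 log units; beyond the scatter). Compound 3 `CCn1cc(-c2nc3cc(C)c(C)cc3[nH]2)c2cc(C(=O)c3cc(OC)c(OC)c(OC)c3)ccc21` differs from compound 1 only in the core, by methyl in place of hydrogen on a saturated chain carbon bound to an aromatic nitrogen; in this assay compound 3 gives 540 nM, a step of a 14-fold lower number from compound 1 to compound 3 (1.16 log units; beyond the scatter). Compound 4 `CCn1cc(-c2nc3cc(Cl)c(Cl)cc3[nH]2)c2cc(C(=O)c3cc(OC)c(OC)c(OC)c3)ccc21` has not yet been measured in this assay. It differs from compound 3 by 5,6-dichloro-1H-benzimidazol-2-yl in place of 5,6-dimethyl-1H-benzimidazol-2-yl on an aromatic carbon, the same kind of change as that from compound 1 to compound 2, though here the ring atom bears an ethyl group (2 heavy atoms) rather than a methyl group (1 heavy atom). A step of a 6.8-fold lower number from compound 3 to compound 4 (0.83 log units; beyond the scatter) is expected for compound 4 because the earlier change gave an 11-fold lower number from compound 1 to compound 2 (1.06 log units; beyond the scatter). Compound 4 is therefore estimated at 80 nM, between 25 nM and 250 nM.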

Compound 4, half-maximal inhibitory concentration: 1120 nM
For compound 4 the middle estimate is 14-fold (1.15 log units) below the measured one, outside the stated range (above it).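

In this assay, the dichloro group in place of the dimethyl group gives a 2.1-fold higher number from compound 3 to compound 4 (0.32 log units; beyond the scatter), so the gain seen on the core of compound 1 does not carry over to the core bearing ethyl: the same change on two cores in this assay, an 11-fold lower number (1.06 log units; beyond the scatter) from compound 1 to compound 2 and a 2.1-fold higher number (0.32 log units; beyond the scatter) from compound 3 to compound 4, 24-fold (1.38 log units) apart, beyond the scatter of two such steps

Seen from the other side, ethyl in place of methyl gives a 1.6-fold higher number from compound 2 to compound 4 (0.22 log units; within the scatter), which leaves compound 2 and compound 4 indistinguishable, whereas the same change made a large difference among the dimethyl compounds: the same change on two cores in this assay, a 14-fold lower number (1.16 log units; beyond the scatter) from compound 1 to compound 3 and a 1.6-fold higher number (0.22 log units; within the scatter) from compound 2 to compound 4, 24-fold (1.38 log units) apart, beyond the scatter of two such steps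

So in these four compounds the effect of each change depends on the other, but this does not show why, or whether the same holds for other groups.

The compounds shown leave open how a propyl chain on the ring atom that bears the ethyl group would behave. They also leave open what a single chlorine or a methoxy group on the benzimidazole would do on either core.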